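This account rests on a few compounds, and the source may have more. Where it says the series, first, only, none or still open, it means among the compounds named here.

Measured compounds:
- compound 1, `COc1ccc(Cl)cc1-n1ncc(-c2nnc(-c3cccc(F)c3)o2)c1C`: 4.28
- compound 2, `COc1ccc(Cl)cc1-n1ncc(-c2nnc(-c3ccc(C)c([N+](=O)[O-])c3)o2)c1C`: 6.42
- compound 3, `COc1ccc(Cl)cc1-n1ncc(-c2nnc(-c3ccc(Br)cc3)o2)c1C`: 4.88

All three share one core and differ only in the aromatic ring attached to it. In a physicochemical assay for lipophilicity, using the shake flask method, measured as octanol-water partition (on this read-out higher numbers stand for higher lipophilicity and lower numbers for lower lipophilicity), compound 3 gives 4.88, which places it second highest of the three: compound 1 gives 4.28, a step of a number 0.60 log units higher from compound 1 to compound 3 (beyond the scatter), while compound 2 gives 6.42, a step of a number 1.54 log units lower from compound 2 to compound 3 (beyond the scatter). Compound 4, `COc1ccc(Cl)cc1-n1ncc(-c2nnc(-c3ccc(Cl)c(Cl)c3)o2)c1C`, has not yet been measured. It differs from compound 3 in one place: 3,4-dichlorophenyl in place of 4-bromophenyl on an aromatic carbon.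

Among the measured compounds shown here, two measured steps bear on this change. The swap of one halogen for another on the same ring, a number 0.60 log units higher from compound 1 to compound 3 (beyond the scatter), was modest; the larger step of a number 1.54 log units lower from compound 2 to compound 3 (beyond the scatter) involved a ring with a nitro group and a methyl group, and so speaks less directly to a halogen exchange. Adding a second chlorine in place of bromine is therefore expected to give compound 4 a modest step upward in this assay, a number 0.42 log units higher from compound 3 to compound 4 (beyond the scatter). Compound 4 is estimated at 5.3, with a range from 4.8 to 5.9.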

Compound 4, partition coefficient: 5.57
Compound 4: the middle estimate sits 0.27 log units below what was measured; the measured number falls inside the stated range.
By their numbers in this assay, from the lowest: compound 1; then compound 3; then compound 4; then compound 2.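

This position on the shared core now holds a third halogen-bearing ring, and in this assay the 3,4-dichlorophenyl ring stands highest of the three (a number 0.69 log units higher from compound 3 to compound 4 (beyond the scatter); a number 1.29 log units higher from compound 1 to compound 4 (beyond the scatter)). Two chlorines still do not reach the ring with the nitro and methyl groups (a number 0.85 log units lower from compound 2 to compound 4 (beyond the scatter)), so compound 2 goes against any reading in which halogens alone set the top of the order. Nothing available here explains why these steps have the sizes they do.

The compounds shown leave open what a phenyl ring carrying an amine or a carboxylic acid would give at this position. Compound 4 also changes the halogen and adds a second one in a single step, so the two changes cannot be told apart.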